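From 2-cyanoethyl to 2-cyanoethenyl on the shared core

The source may report more compounds than this note shows. Statements on the series, on what has been measured and on what is new or still open speak of the compounds shown alone.

In a physicochemical assay for solubility, with a stated time of 4 h, at pH 7.4 (on this read-out lower numbers stand for lower solubility and higher numbers for higher solubility), compound 3 `COC(=O)c1cc(N)c(Nc2ccc(C#N)cc2)cc1Oc1c(C)cc(CCC#N)cc1C` gives 1.21 ug/mL. That number lies within the usual scatter of compound 1 `Cc1cc(/C=C/C#N)cc(C)c1Oc1cc(Nc2ccc(C#N)cc2)c(N)cc1C(N)=O`, which gives 0.63 ug/mL. It lies beyond the scatter of compound 2 `Cc1cc(/C=C/C#N)cc(C)c1Oc1cc(Nc2ccc(C#N)cc2)c(N)cc1[N+](=O)[O-]`, which gives 0.29 ug/mL.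

Compound 4 `COC(=O)c1cc(N)c(Nc2ccc(C#N)cc2)cc1Oc1c(C)cc(/C=C/C#N)cc1C` differs from compound 3 in one place, with 2-cyanoethenyl in place of 2-cyanoethyl on an aromatic carbon.

Among the compounds with values here, no measured pair makes this exact change, so the evidence is indirect. Within the data shown here, the only measured single change is a 2.2-fold lower number from compound 1 to compound 2 (0.34 log units; beyond the scatter), with nitro in place of carbamoyl on an aromatic carbon. It leaves the 2-cyanoethenyl group untouched, so it offers only a sense of the size a single change can have in this small set. Among the measured compounds shown here, compounds 1 and 2 both carry the 2-cyanoethenyl group that compound 4 will carry, and compound 1 at 0.63 ug/mL and compound 2 at 0.29 ug/mL are the only guide to the direction. They differ from compound 4 elsewhere too, so the guide is weak. A modest downward move in this assay is therefore expected, and the expected step is a 2.2-fold lower number from compound 3 to compound 4 (0.34 log units; beyond the scatter). The estimate for compound 4 is 0.55 ug/mL, with an expected range from 0.22 ug/mL to 1.2 ug/mL.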

Compound 4, solubility: 1.3 ug/mL
The estimate for compound 4 lay 2.4-fold (0.37 log units) below the measured number; the whole stated range lies below it.
By their numbers in this assay, from the lowest: compound 2; then compounds 1, 3 and 4 (each within the scatter of the next, the first and the last beyond it).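

In this assay, 2-cyanoethenyl in place of 2-cyanoethyl gives a 1.1-fold higher number from compound 3 to compound 4 (0.03 log units; within the scatter) on this shared core, so at this position, meta to two methyl groups, the added double bond in the chain leaves the two compounds indistinguishable on this read-out. With 2-cyanoethenyl held in place, methoxycarbonyl in place of nitro gives a 4.5-fold higher number from compound 2 to compound 4 (0.65 log units; beyond the scatter) and methoxy in place of amino on a carbonyl carbon gives a 2.1-fold higher number from compound 1 to compound 4 (0.31 log units; beyond the scatter) as modest steps, so among these compounds the steps beyond the scatter all come from the group at that other site, not from the chain. Nothing measured here offers an explanation for these numbers.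

From the compounds shown here alone, only these two chains are seen at this position, so it remains open whether a longer chain, or one ending in an amine or a carboxylic acid, would read the same. Going by these compounds, it also remains open whether 2-cyanoethyl and 2-cyanoethenyl would stay indistinguishable alongside carbamoyl or nitro; here 2-cyanoethyl appears only with methoxycarbonyl.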